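The compounds below may be only part of what the source reports. "The series", "measured", "known", "first", "only" and "open" are said of these compounds alone.

Of the compounds shown here, two have so far been tested in a functional assay on MDA-MB-468 cells (Homo sapiens) for inhibition, read by sulforhodamine B assay, with a stated time of 48 h, tested at 10 uM; a higher number here means a weaker effect of the compound at the concentration tested, a lower number a stronger effect. Compound 1 `COc1cc(Cl)cc(-c2nn(-c3cccc(NC(=O)c4ccc(Cl)c(Cl)c4)c3)cc2-c2ccncc2)c1` gives 54.6% in this assay, whereas compound 2 `O=C(Nc1cccc(-n2cc(-c3ccncc3)c(-c3cc(O)cc(Cl)c3)n2)c1)Nc1ccc(Cl)c(C(F)(F)F)c1` gives 5.22%. Compound 2 therefore stands at the lowest of the two numbers, and its nearest neighbour, compound 1, lies higher by a margin beyond the usual scatter. Compound 3 `COc1cc(Cl)cc(-c2nn(-c3cccc(NC(=O)Nc4ccc(Cl)c(C(F)(F)F)c4)c3)cc2-c2ccncc2)c1` has not yet been measured. It differs from compound 2 in a single place: methyl in place of hydrogen on an oxygen on an aromatic ring. Within the data shown here, no pair of measured compounds shows this change by itself, so the expectation rests on compound 2 alone. Because compound 2 gives 5.22%, only a small upward step, a number 9.8 percentage points higher from compound 2 to compound 3 (within the scatter), is expected for compound 3, and it may stay within the scatter. Compound 3 is thus estimated at 15%, with a likely range from 3% to 45%.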

Compound 3, a percentage reported as activity, at one concentration (the size of the read-out at that concentration, not a potency): -14.4%
The estimate for compound 3 lay 29.4 percentage points above the measured number; the measured number lies below the stated range.
By their numbers in this assay, from the lowest: compound 3; then compound 2; then compound 1.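

In this assay, hydroxy to methoxy on the aromatic ring gives a number 19.6 percentage points lower from compound 2 to compound 3 (beyond the scatter), so placing methyl on this oxygen does not lose the effect, and the hydrogen there is not required for it. With the methoxy group held constant, (4-chloro-3-(trifluoromethyl)phenyl)amino in place of 3,4-dichlorophenyl on the carbonyl carbon gives a number 69 percentage points lower from compound 1 to compound 3 (beyond the scatter), a large step beside the modest change at the oxygen. Nothing available explains why either change strengthens the effect.

Going by these compounds, it remains open whether a longer chain on this oxygen, such as ethyl, or an amine in place of the hydroxy group would keep the effect. Also open, on these data alone, is how 3-chloro-5-hydroxyphenyl would behave alongside 3,4-dichlorophenyl, a combination absent from these three compounds.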